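The source may report more compounds than this note shows. Statements on the series, on what has been measured and on what is new or still open speak of the compounds shown alone.

Compound 1 `CC(C)(C)c1ccc(CNCCNS(=O)(=O)c2cc(C(F)(F)F)cc(C(F)(F)F)c2)cc1` gives 13000 nM in a functional assay on MCF7 cells (Homo sapiens) for inhibition, read by MTT assay, with a stated time of 72 h; a lower number here means a stronger inhibitor of growth, a higher number a weaker inhibitor of growth. Compound 2 `O=S(=O)(NCCNCc1ccc(-c2ccccc2)cc1)c1cc(C(F)(F)F)cc(C(F)(F)F)c1` gives 1400 nM. Compound 3 `O=S(=O)(NCCCNCc1ccc(C(F)(F)F)cc1)c1cc(C(F)(F)F)cc(C(F)(F)F)c1` gives 1400 nM.

Compound 3 and compound 2 share the lowest numbers of the three; the two values are within the scatter of each other, and both sit far from compound 1. Among the measured compounds shown here, the only one-place step measured, a 9.3-fold lower number from compound 1 to compound 2 (0.97 log units; beyond the scatter), swaps a group at the outer end of the molecule. Compound 4 `O=S(=O)(NCCCNCc1ccc(Cl)c(Cl)c1)c1cc(C(F)(F)F)cc(C(F)(F)F)c1` differs from compound 3 by 3,4-dichlorophenyl in place of 4-(trifluoromethyl)phenyl on a saturated chain carbon bound to an amine nitrogen. For the measured compounds named here, no measured step changes the same part in this way, so the one step bears only loosely on it. A change of this kind is expected to stay near the scatter, and compound 4 is estimated at 1200 nM (range 400 nM to 4000 nM), a step of a 1.2-fold lower number from compound 3 to compound 4 (0.07 log units; within the scatter).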

Compound 4, concentration for 50% growth inhibition: 2400 nM
Compound 4: the middle estimate sits 2.0-fold (0.30 log units) below what was measured; the range from low to high includes it.
By their numbers in this assay, from the lowest: compounds 2, 3 and 4 (each within the scatter of the next); then compound 1.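

In this assay the swap of 4-(trifluoromethyl)phenyl for 3,4-dichlorophenyl gives a 1.7-fold higher number from compound 3 to compound 4 (0.23 log units; within the scatter) and so leaves the two compounds indistinguishable. This is the first step shown at this place on the saturated chain carbon bound to an amine nitrogen, and here the two aromatic groups serve equally well. Nothing measured explains this match.

From the compounds shown here alone, what a carboxylic acid or an amine on this ring would do remains open. So does whether a pyridine ring could stand in place of the benzene ring.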